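Swapping 4-fluorophenyl for 3,4-dichlorophenyl on a shared core

The compounds below may be only part of what the source reports. "The series", "measured", "known", "first", "only" and "open" are said of these compounds alone.

In an ADME assay on L02 cells (Homo sapiens) for cytotoxicity, read by MTT assay, with a stated time of 24 h (a lower number here means a stronger inhibitor, a higher number a weaker inhibitor), compound 1 (`CN1C/C(=C\c2ccc(C#N)cc2)C(=O)/C(=C/c2ccccc2F)C1`) gives 11000 nM and compound 2 (`COc1cc(/C=C2\CN(C)C/C(=C\c3ccc(F)cc3)C2=O)cc(OC)c1`) gives 21900 nM as a read-out. Compound 3 (`COc1cc(/C=C2\CN(C)C/C(=C\c3ccc(F)cc3)C2=O)cc(OC)c1OC`) gives 10700 nM and so sits level with compound 1 within the scatter of repeated measurements, while compound 2 shows the higher number.

For the measured compounds named here, compound 4 (`COc1cc(/C=C2\CN(C)C/C(=C\c3ccc(Cl)c(Cl)c3)C2=O)cc(OC)c1OC`) has no measurement yet. In it, 3,4-dichlorophenyl stands in place of 4-fluorophenyl on a double-bonded chain carbon bound to a double-bonded ring carbon (3,4-dichlorophenyl in place of 4-fluorophenyl on a double-bonded chain carbon bound to a double-bonded ring carbon).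

Going by the values given here, no measured step touches that place, so any expectation rests on thin evidence. Among the compounds with values here, the only measured single change is a 2.0-fold lower number from compound 2 to compound 3 (0.31 log units; beyond the scatter) with methoxy in place of hydrogen on an aromatic carbon. That modest step lies at another place on the molecule, so it offers only a rough guide to how far one local change can move the number in this small set. Compound 1 differs from compound 3 in more than one place and cannot isolate the change.

A small drop is therefore expected, with no firm direction. The estimated change is a 1.3-fold lower number from compound 3 to compound 4 (0.10 log units; within the scatter) and may not exceed the scatter. For compound 4 the expected value is 8500 nM with an estimated range from 3500 nM to 20000 nM in this assay once it is measured.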

Compound 4, half-maximal inhibitory concentration: 18400 nM
For compound 4 the middle estimate is 2.2-fold (0.34 log units) below the measured one; the measured number falls inside the stated range.
By their numbers in this assay, from the lowest: compounds 3, 1, 4 and 2 (each within the scatter of the next, the first and the last beyond it).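

In this assay, for the compounds shown here, the swap of 4-fluorophenyl for 3,4-dichlorophenyl on a double-bonded chain carbon bound to a double-bonded ring carbon gives the first reading at this position: a 1.7-fold higher number from compound 3 to compound 4 (0.24 log units; within the scatter). For this one pair, a ring with two chlorine atoms in place of a ring with one fluorine atom, one heavy atom larger overall, leaves the two compounds indistinguishable in this assay, so the swap has no effect that can be told apart from ordinary repeat variation. Nothing in the information available accounts for this result or shows what a larger or different group would do here.

From the compounds shown here alone, because this position is represented by a single pair of halogen-bearing phenyl groups on one version of the shared core, it remains open whether a phenyl group carrying an amine or a carboxylic acid at the same place would shift the number beyond the scatter. Going by these compounds, it is also open whether the same swap would read the same way on the core of compound 2, which carries one methoxy group fewer than compound 3.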